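The source may hold more compounds than are shown below. What is called first, only, known or untested is meant among the compounds shown, and "the series" means these compounds.

Of the compounds shown here, three have so far been measured in a functional assay on SK-MEL-28 cells (Homo sapiens) for inhibition, read by colorimetric assay and MTT assay, with a stated time of 72 h; on this read-out lower numbers stand for stronger inhibition and higher numbers for weaker inhibition. Compound 1 `C=CCCCCOc1cc2ccccc2cc1-c1cnc(OCCC=C)n1C` gives 25000 nM in this assay, and compound 2 `C=CCCCCOc1cc2ccccc2cc1-c1cnc(OCCCCC=C)n1C` gives 59000 nM in this assay. These two share a core and differ in one place, namely (vinyl in place of but-3-en-1-yl on a saturated chain carbon, two bonds along the chain from an oxygen on an aromatic ring), and the step that goes with it is a 2.4-fold lower number from compound 2 to compound 1 (0.37 log units; beyond the scatter). Compound 3 `C=CCCCCOc1ccccc1-c1cnc(S(=O)(=O)c2ccccc2)n1C` gives 38000 nM in this assay; it stands on a different core, and the difference between the two cores is not broken down here. Its value lies within the scatter of compound 1 and within the scatter of compound 2, so no order between it and either of them is drawn.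

Compound 4 `C=CCCOc1ccccc1-c1cnc(S(=O)(=O)c2ccccc2)n1C` has not yet been measured. It differs from compound 3 by the same change as the one above, (vinyl in place of but-3-en-1-yl on a saturated chain carbon, two bonds along the chain from an oxygen on an aromatic ring), made at the same kind of place. Since that change on the other core gave a 2.4-fold lower number from compound 2 to compound 1 (0.37 log units; beyond the scatter), a step of similar size is expected for compound 3 when it becomes compound 4: a 2.4-fold lower number from compound 3 to compound 4 (0.38 log units; beyond the scatter). This expectation rests on a single measured pair. Compound 4 is accordingly estimated to give 16000 nM in this assay, with a likely range from 6000 nM to 45000 nM.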

Compound 4, half-maximal inhibitory concentration: 60000 nM
The estimate for compound 4 lay 3.8-fold (0.57 log units) below the measured number, and the stated range ends below it.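

In this assay, going from hex-5-en-1-yl to but-3-en-1-yl on the core of compound 3 gives a 1.6-fold higher number from compound 3 to compound 4 (0.20 log units; within the scatter), so no order is drawn between these two compounds. The change therefore did not carry its effect over from the core of compound 1 to the core of compound 3, and the two steps differ: the same change on two cores in this assay, a 2.4-fold lower number (0.37 log units; beyond the scatter) from compound 2 to compound 1 and a 1.6-fold higher number (0.20 log units; within the scatter) from compound 3 to compound 4, 3.7-fold (0.57 log units) apart, beyond the scatter of two such steps. This shows that, in this series, a step measured on one core cannot be assumed to hold on the other, but with a single pair on each core it does not show which feature of the cores goes with the difference, or how the change would behave on any further core.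

The compounds shown leave open how either core would respond to a saturated chain such as butyl or hexyl, or to a chain ending in an amine or a carboxylic acid. They also leave open whether a shorter chain such as allyl, or a longer chain such as oct-7-en-1-yl, would follow either step.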